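Triazole substituent swap in a dibenzyloxy furanone series

The compounds below may be only part of what the source reports. "The series", "measured", "known", "first", "only" and "open" are said of these compounds alone.

Going by the values given here, compound 3 `O=C1O[C@H]([C@@H](O)Cn2cc(-c3cccc(O)c3)nn2)C(OCc2ccccc2)=C1OCc1ccccc1` is the only member with a full number in a functional assay on CFPAC-1 cells (Homo sapiens) for antiproliferative activity, read by MTT assay, with a stated time of 72 h; on this read-out higher numbers stand for weaker inhibition and lower numbers for stronger inhibition: compound 3 gives 54100 nM. Compound 1 `Cc1ccc(-c2cn(C/C=C3\OC(=O)C(OCc4ccccc4)=C3OCc3ccccc3)nn2)cc1` reaches only a limit in this assay, > 100000 nM. Compound 2 `O=C1O/C(=C\Cn2cc(-c3cc(F)cc(F)c3)nn2)C(OCc2ccccc2)=C1OCc1ccccc1` is recorded in this assay as "not active" (no number reported), without a number. Among the compounds with values here, no step between two measured compounds can therefore be counted. Compound 4 `O=C1O[C@H]([C@@H](O)Cn2cc(CNS(=O)(=O)c3ccc(F)cc3)nn2)C(OCc2ccccc2)=C1OCc1ccccc1` carries (((4-fluorophenyl)sulfonyl)amino)methyl in place of 3-hydroxyphenyl on an aromatic carbon, that is, (((4-fluorophenyl)sulfonyl)amino)methyl in place of 3-hydroxyphenyl on an aromatic carbon. Within the data shown here, with no measured step as guide, the expected step of a 1.3-fold higher number from compound 3 to compound 4 (0.11 log units; within the scatter) is small, within the scatter or leaning toward weaker inhibition. Compound 4 is estimated at 70000 nM in this assay, expected to fall between 25000 nM and 200000 nM.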

Compound 4, half-maximal inhibitory concentration: 34700 nM
Compound 4: the middle estimate sits 2.0-fold (0.30 log units) above what was measured, and the stated range covers the measured number.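

At this position on the five-membered aromatic ring with 3 nitrogen, (((4-fluorophenyl)sulfonyl)amino)methyl and 3-hydroxyphenyl read alike in this assay, with a 1.6-fold lower number from compound 3 to compound 4 (0.19 log units; within the scatter). This first countable step shows that the larger group leaves the read-out within the scatter, so this change alone gives no gain in inhibition. Compound 1 reaches only a limit: the limit of > 100000 nM in this assay, at which 1 of the 4 values shown sits.

From the compounds shown here alone, whether an amine or a carboxylic acid at this position would give a step beyond the scatter remains open. Also open, going by these compounds, is the effect of a longer chain between the ring and the sulfonyl group.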